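This account rests on a few compounds, and the source may have more. Where it says the series, first, only, none or still open, it means among the compounds named here.

Of the compounds shown here, two of a shared core have been measured for how strongly they curb the growth of a prostate cancer cell line. Compound 1 `OC[C@@H]1C[C@H](CO)[C@@H]2C(c3ccc(Cl)cc3)=NO[C@H]12` carries a chloro group on its outer aromatic ring. In a functional assay on PC-3 cells (Homo sapiens) for cytotoxicity, read by MTT assay, with a stated time of 48 h (on this read-out higher numbers stand for weaker inhibition and lower numbers for stronger inhibition), compound 1 gives > 50 ug/mL, which is a limit of the assay and not a measured number. Compound 1 therefore stands at the limit of > 50 ug/mL in this assay, at which 1 of the 2 values shown sits, so its true potency is known only to lie beyond that point. Compound 2 `OC[C@@H]1C[C@H](CO)[C@@H]2C(c3ccc4ccccc4c3)=NO[C@H]12` carries a larger fused aromatic system in the same position; in this assay compound 2 gives 48.4 ug/mL, a measured number.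

Compound 3 `OC[C@@H]1C[C@H](CO)[C@@H]2C(c3ccc(Br)cc3)=NO[C@H]12` is the next compound to be tested. It differs from compound 1 in one spot: bromo in place of chloro on an aromatic carbon. Among the compounds with values here, because the only guide is the limit of > 50 ug/mL in this assay, at which 1 of the 2 values shown sits, of compound 1, no sizeable shift is anticipated. The step of a number no higher from compound 1 to compound 3 (the limit leaves the size open) is expected to stay within the usual scatter, with a fair chance that only a limit is reported again. Compound 3 is estimated at 50 ug/mL, within a range of 25 ug/mL to 100 ug/mL.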

Compound 3, half-maximal inhibitory concentration: > 50 ug/mL
Compound 3 gave a limit, no number; the forecaster's own chance of this, stated with the estimate: 60%; the middle value sits exactly at the limit.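

In this assay compound 3 gives > 50 ug/mL, a limit of the assay and not a number. Within the data shown here, compound 1 also stands at a limit, so no step from chloro to bromo can be read between compound 1 and compound 3. The true potency of both compounds stays open, as does whether the two differ at all: the limit of > 50 ug/mL in this assay, at which 2 of the 3 values shown sit.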